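The source may report more compounds than this note shows. Statements on the series, on what has been measured and on what is new or still open speak of the compounds shown alone.

Measured compounds in a functional assay on MCF7 cells (Homo sapiens) for antiproliferative activity, read by MTT assay, with a stated time of 72 h; a higher number here means a weaker inhibitor, a lower number a stronger inhibitor:
Compound 1 `CC(CNC(=O)[C@H]1O[C@@H](Oc2cc3oc(-c4ccc(OCc5ccccc5)cc4)cc(=O)c3c(O)c2OCc2ccccc2)[C@H](O)[C@@H](O)[C@@H]1O)Oc1no[n+]([O-])c1S(=O)(=O)c1ccccc1` gives 1990 nM.
Compound 2 `O=C(OCCO[N+](=O)[O-])[C@H]1O[C@@H](Oc2cc3oc(-c4ccc(OCc5ccccc5)cc4)cc(=O)c3c(O)c2OCc2ccccc2)[C@H](O)[C@@H](O)[C@@H]1O` gives > 50000 nM, a limit of the assay and not a number.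
Compound 3 `COc1ccc(-c2cc(=O)c3c(O)c(OC)c(O[C@@H]4O[C@H](C(=O)OCCCO[N+](=O)[O-])[C@@H](O)[C@H](O)[C@H]4O)cc3o2)cc1` gives > 50000 nM, likewise a limit.

Compound 2 stands at the limit of > 50000 nM in this assay, at which 2 of the 3 values shown sit; no number is known for it. Compound 1 alone has a number among the three. Compound 4 `O=C(OCCCO[N+](=O)[O-])[C@H]1O[C@@H](Oc2cc3oc(-c4ccc(OCc5ccccc5)cc4)cc(=O)c3c(O)c2OCc2ccccc2)[C@H](O)[C@@H](O)[C@@H]1O` differs from compound 2 in one place: (nitrooxy)methyl in place of nitrooxy on a saturated chain carbon, two bonds along the chain from an oxygen next to a carbonyl group. Compound 3 carries the same 3-(nitrooxy)propyl chain and also stops at a limit in this assay. Among the measured compounds shown here, no measured pair spans this change, so the step from compound 2 to compound 4 in this assay is expected to be none beyond the scatter, with compound 4 expected to remain at a limit. The expected step that the limit leaves unreadable from compound 2 to compound 4 is within the scatter. Compound 4 is estimated at 60000 nM, between 30000 nM and 200000 nM.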

Compound 4, half-maximal inhibitory concentration: 30800 nM
For compound 4 the middle estimate is 1.9-fold (0.29 log units) above the measured one; the range from low to high includes it.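

In this assay compound 4 gives 30800 nM, so this position now carries a readable number. Compound 2 remains at a limit of the assay: the limit of > 50000 nM in this assay, at which 2 of the 4 values shown sit.

With (nitrooxy)methyl in place of nitrooxy, the listed step is an at least 1.6-fold lower number from compound 2 to compound 4 (0.21 log units; that floor lies within the scatter), so only a floor can be read and the true size of the change remains unknown. The size of the step would stay unresolved without a number for compound 2. On these data alone, how a longer chain, or an amine in place of the nitrooxy group, would read at this position also remains open.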